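Cyclopropylmethoxy in place of methoxy: compound 3

This account rests on a few compounds, and the source may have more. Where it says the series, first, only, none or still open, it means among the compounds named here.

Measured so far:
compound 1, `COc1ccc(-c2ccn(CCC(C)C)c(=O)c2C#N)cc1F`: 1170 nM
compound 2, `COc1ccc(-c2ccn(CCC(C)C)c(=O)c2C#N)cc1Cl`: 363 nM

Two compounds have been run in a functional assay on CHO cells for positive allosteric modulation of metabotropic glutamate receptor 2 (Homo sapiens), read by scintillation counting and GTPgammaS binding, with a stated time of 30 min; a lower number here means that less compound is needed, a higher number that more compound is needed for the effect. Going by the values given here, compound 1 gives 1170 nM and compound 2 gives 363 nM; the single step between them, chloro in place of fluoro on an aromatic carbon, is a 3.2-fold lower number from compound 1 to compound 2 (0.51 log units; beyond the scatter). Among the compounds with values here, compound 2 thus stands at the lowest of the two numbers, with compound 1 its only neighbour.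

Compound 3 `CC(C)CCn1ccc(-c2ccc(OCC3CC3)c(Cl)c2)c(C#N)c1=O` keeps the chloro of compound 2 and differs by cyclopropyl in place of hydrogen on a saturated chain carbon bound to an oxygen on an aromatic ring. Within the data shown here, no measured step touches the alkoxy group: the fluoro-to-chloro step says nothing about extending methoxy to cyclopropylmethoxy, so the size and direction of this step are unsupported by the numbers in hand. A step of modest size, within or just beyond the scatter, is the working expectation. For compound 3 the estimate is 200 nM, with a range of 60 nM to 700 nM. That estimate would mean an expected 1.8-fold lower number from compound 2 to compound 3 (0.26 log units; within the scatter).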

Compound 3, half-maximal effective concentration: 110 nM
Compound 3: the middle estimate sits 1.8-fold (0.26 log units) above what was measured, within the range that was stated.
By their numbers in this assay, from the lowest: compound 3; then compound 2; then compound 1.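

Methoxy to cyclopropylmethoxy gives a 3.3-fold lower number from compound 2 to compound 3 (0.52 log units; beyond the scatter) in this assay and makes the alkoxy group a second place in the series where the number moves. Until now only the halogen on the aromatic ring had changed; this step shows that the saturated chain carbon bound to the oxygen can carry a three-membered ring while the number goes down, beyond the scatter. Nothing in hand explains the size or direction of this step.

As far as these compounds go, whether the ring itself matters or only the added carbon stays open: an open chain such as ethyl or isobutyl on the oxygen would separate the two. Also open, from the compounds shown here alone, is whether a larger ring, such as cyclobutyl, continues the trend or reverses it, and whether the step holds with fluoro in place of chloro.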